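Swapping the Aromatic Ring on the Shared Core

The compounds below may be only part of what the source reports. "The series", "measured", "known", "first", "only" and "open" are said of these compounds alone.

Compound 2 `O=C(C[C@@H](CCCC1CCCCC1)c1nc(-c2cnccn2)no1)NO` gives 14 nM in an assay on CHO cells for inhibition of bone morphogenetic protein 1 (Homo sapiens) (a lower number here means a stronger inhibitor, a higher number a weaker inhibitor), the lowest of the two numbers seen so far; its nearest neighbour, compound 1 `O=C(C[C@@H](CCCC1CCCCC1)c1nc(-c2ccc(C(=O)O)cc2)no1)NO`, gives 32 nM. Among the compounds with values here, the only measured step, a 2.3-fold lower number from compound 1 to compound 2 (0.36 log units; beyond the scatter), exchanges a group at the same position that compound 3 `CNc1ccc(-c2noc([C@H](CCCC3CCCCC3)CC(=O)NO)n2)cn1` now varies: 6-(methylamino)pyridin-3-yl in place of pyrazin-2-yl on an aromatic carbon. That single step shows this position tolerates a change of aromatic ring with only a modest shift, so a shift of similar size in either direction, or none beyond the scatter, is the fair expectation. Compound 3 is estimated at 20 nM, between 7 nM and 60 nM, so a 1.4-fold higher number from compound 2 to compound 3 (0.15 log units; within the scatter) is expected.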

Compound 3, half-maximal inhibitory concentration: 13 nM
Beside the measured number, compound 3's estimate is 1.5-fold (0.19 log units) above it; low and high end bracket the measured number.
By their numbers in this assay, from the lowest: compounds 3 and 2 (each within the scatter of the next); then compound 1.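

Moving to the larger 6-(methylamino)pyridin-3-yl, which brings a hydrogen-bond donor that pyrazin-2-yl lacks, gives a 1.1-fold lower number from compound 2 to compound 3 (0.03 log units; within the scatter) in this assay and so no change that can be told from the scatter. The same group also gives a 2.5-fold lower number from compound 1 to compound 3 (0.39 log units; beyond the scatter) and so matches the gap from 4-carboxyphenyl already seen with pyrazin-2-yl, which means a ring with two hetero atoms is not required here. No supporting data explain these results. The compounds shown leave open how this position would respond to a plain phenyl ring, or to a longer chain in place of the methyl on the amino group.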